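This account rests on a few compounds, and the source may have more. Where it says the series, first, only, none or still open, it means among the compounds named here.

Measured compounds:
- Compound 1, `CCNC(=O)n1ccc(Cn2c(C(=O)CC)c(-c3ccccc3)c3cc(Cl)ccc3c2=O)n1`, gives 4.51 in a physicochemical assay for lipophilicity, at pH 7.4; on this read-out lower numbers stand for lower lipophilicity and higher numbers for higher lipophilicity.
- Compound 2, `CCC(=O)c1c(-c2ccccc2)c2cc(Cl)ccc2c(=O)n1Cc1cc(S(C)(=O)=O)n(CC(N)=O)n1`, gives 3.42 in this assay.

Within the data shown here, of these two numbers, compound 2 stands lowest; the only other value, that of compound 1, lies higher by a gap beyond the usual scatter of repeated measurements. Among the measured compounds shown here, compound 1 and compound 2 differ from each other in more than one place, so no single structural step connects them, and their two values show only that the two molecules sit apart on this read-out.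

Compound 3 is `CCC(=O)c1c(-c2ccccc2)c2cc(Cl)ccc2c(=O)n1Cc1cc(S(C)(=O)=O)n(CCC(C)(C)O)n1`. It differs from compound 2 in exactly one place: 2-hydroxy-2-methylpropyl in place of carbamoyl on a saturated chain carbon bound to an aromatic nitrogen. For the measured compounds named here, no measured pair shows this same change, so there is no measured step to lean on, and the expectation rests on the structural change alone. In this assay the expected step is a number 0.88 log units higher from compound 2 to compound 3 (beyond the scatter), upward and beyond the scatter. Compound 3 is therefore estimated at 4.3, with a likely range from 3.8 to 4.8.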

Compound 3, distribution coefficient: 4.23
The estimate for compound 3 lay 0.07 log units above the measured number, within the range that was stated.
By their numbers in this assay, from the lowest: compound 2; then compounds 3 and 1 (each within the scatter of the next).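

Among these compounds, for the first time, two measured molecules differ in one place only, so this assay can be read for a single change on a saturated chain carbon bound to an aromatic nitrogen: swapping carbamoyl for 2-hydroxy-2-methylpropyl gives a number 0.81 log units higher from compound 2 to compound 3 (beyond the scatter), a modest step on this one pair. The number therefore responds to what is attached at this place, even though the group that leaves and the group that enters each count 1 hydrogen-bond donor, 1 hydrogen-bond acceptor and no net charge, and differ in their heavy atoms, 3 against 5. Nothing measured here accounts for the size or direction of this step, so it stands as an observation only.

Still open, from the compounds shown here alone, is how the number would respond at this place to a plain ethyl chain, a longer chain without the hydroxyl, an amine or a carboxylic acid, any of which would help separate the contribution of chain length from that of the end group. Also open, going by these compounds, is whether the same swap would give a similar step on a different core, since a single pair cannot show this.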